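The compounds below may be only part of what the source reports. "The series", "measured", "known", "first", "only" and "open" are said of these compounds alone.

Compound 1, `COc1cc(CNC(=O)CCCCCCC(C)C)ccc1OC(=O)CCC(=O)Oc1ccc(C(N)=S)cc1`, has no number in a functional assay on K562 cells (Homo sapiens) for antiproliferative activity, read by MTT assay, with a stated time of 48 h; on this read-out lower numbers stand for stronger inhibition and higher numbers for weaker inhibition: in this assay compound 1 gives "not determined" (no result reported), so there is no measured value to place it against. For the measured compounds named here, the only result comes from compound 2, `COc1cc(CNC(=O)CCCC/C=C/C(C)C)ccc1OCCCCCOc1ccc(-c2cc(=S)ss2)cc1`, which carries the same ring-bearing end group as the unmeasured compound but a different linker. In this assay compound 2 gives > 50000 nM, and this is a limit of the assay rather than a number. That limit is the limit of > 50000 nM in this assay, at which 1 of the 2 values shown sits. Going by the values given here, compound 3, `COc1cc(CNC(=O)CCCCCCC(C)C)ccc1OC(=O)CCC(=O)Oc1ccc(-c2cc(=S)ss2)cc1`, is still to be measured. a group of 6 heavy atoms (3 carbon, 3 sulfur; one five-membered aromatic ring with 2 hetero atoms) in place of a group of 3 heavy atoms (1 carbon, 1 nitrogen, 1 sulfur; no ring), on an aromatic carbon Since compound 1 has no value and no step between measured compounds is available, the size of this change cannot be read from a comparison, and no direction can be claimed beyond the scatter. Among the compounds with values here, what is known is only that compound 2, sharing the entering group, sits at the limit. Compound 3 is therefore expected to land in a similar weak region, with an estimate of 40000 nM and a likely range from 10000 nM to 100000 nM, and a real chance that only a limit is reported.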

Compound 3, half-maximal inhibitory concentration: 5930 nM
For compound 3 the middle estimate is 6.7-fold (0.83 log units) above the measured one, and the stated range ends above it.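

In this assay compound 3 gives 5930 nM, but no step can be read from it, since compound 1 has no reported result and compound 2 differs from compound 3 in more than one place. Compound 2 has a limit of the assay rather than a number: the limit of > 50000 nM in this assay, at which 1 of the 3 values shown sits. The compounds shown leave open how swapping the group on the aromatic carbon changes antiproliferative activity.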